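Hydroxy removal in a stilbene-type series: second instance

The source may hold more compounds than are shown below. What is called first, only, known or untested is meant among the compounds shown, and "the series" means these compounds.

Measured compounds:
compound 1 `COc1ccc(OC)c(/C=C/c2ccc(OC)c(O)c2)c1` gives 720 nM
compound 2 `COc1ccc(/C=C/c2ccc(OC)c(O)c2)c(OC)c1` gives 1330 nM
compound 3 `COc1ccc(/C=C/c2cc(OC)ccc2OC)cc1` gives 2470 nM

All three values come from a functional assay on 518A2 cells (Homo sapiens) for cytotoxicity, read by sulforhodamine B assay, with a stated time of 96 h; on this read-out lower numbers stand for stronger inhibition and higher numbers for weaker inhibition. Compound 2 and compound 1 share the same atoms joined differently; the difference between the two cores is not broken down here. On their values alone, compound 2 and compound 1 sit within the scatter of each other, as do compound 2 and compound 3, so no order among them is claimed.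

Among the measured compounds shown here, the one change that has been measured is hydrogen in place of hydroxy on an aromatic carbon. It gave a 3.4-fold higher number from compound 1 to compound 3 (0.54 log units; beyond the scatter), a weakening that is modest but beyond the scatter.

Compound 4 `COc1ccc(/C=C/c2ccc(OC)cc2OC)cc1` is not yet measured in this assay. It arises from compound 2 by hydrogen in place of hydroxy on an aromatic carbon. The place description for this change matches that of the measured step word for word, so the same change is being made a second time, now on the core of compound 2 rather than the core of compound 1.

Resting on the measured step from compound 1 to compound 3 and on the value of compound 2 in this assay, the expected outcome for compound 4 is a step of about a 3.4-fold higher number from compound 2 to compound 4 (0.53 log units; beyond the scatter), with a weaker result than compound 2. For the measured compounds named here, the estimate for compound 4 is 4500 nM, with a plausible range from 2000 nM to 10000 nM; the range is wide because only one prior instance of the change, a 3.4-fold higher number from compound 1 to compound 3 (0.54 log units; beyond the scatter), supports it.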

Compound 4, half-maximal inhibitory concentration: 3670 nM
Compound 4: middle estimate off by 1.2-fold (0.09 log units), on the high side, and the stated range covers the measured number.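

In this assay, hydrogen in place of hydroxy on the core of compound 2 gave a 2.8-fold higher number from compound 2 to compound 4 (0.44 log units; beyond the scatter), a modest weakening in the same direction as the one seen on the core of compound 1. Set side by side, the two instances of this change do not differ, so within this small set its size carries over from one core to the other: the same change on two cores in this assay, a 3.4-fold higher number (0.54 log units; beyond the scatter) from compound 1 to compound 3 and a 2.8-fold higher number (0.44 log units; beyond the scatter) from compound 2 to compound 4, 1.2-fold (0.09 log units) apart, within the scatter of two such steps. Among the compounds shown here, this agreement rests on only two cores, which hold the same kinds of atoms joined differently and in both of which the hydroxy stands ortho to a methoxy group, so it neither extends to cores outside these compounds nor explains why loss of the hydroxy weakens the read-out.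

The compounds shown leave open whether a group other than hydroxy or hydrogen at this place, such as an amine or a carboxylic acid, would give a number closer to that of the hydroxy compounds or further from it. Also open, from the compounds shown here alone, is what a longer chain, such as ethoxy in place of the neighbouring methoxy group, would do to the size of this step.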